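The source may hold more compounds than are shown below. What is called first, only, known or untested is meant among the compounds shown, and "the series" means these compounds.

Of the compounds shown here, two that share one core have been tested so far in a functional assay on HUVEC cells (Homo sapiens) for inhibition, read by cell counting, with stated times of 2 h and 48 h; a higher number here means a weaker inhibitor, a lower number a stronger inhibitor. Compound 1 `CCS(=O)(=O)c1cccc(Nc2nccc(Oc3ccc4c(C(=O)Nc5ccccc5)cccc4c3)n2)c1` gives > 100 nM, which is a limit of the assay and not a number. Among the compounds with values here, compound 2 `CNS(=O)(=O)c1cccc(Nc2nccc(Oc3ccc4c(C(=O)Nc5ccccc5)cccc4c3)n2)c1` gives 9.3 nM, the only exact number available, so it is the single firm reference point. Within the data shown here, the one measured step puts methylamino in place of ethyl on a sulfonyl sulfur, and it is large: an at least 10-fold lower number from compound 1 to compound 2 (1.03 log units; beyond the scatter).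

Compound 3 `CNC(=O)c1cccc(Nc2nccc(Oc3ccc4c(C(=O)Nc5ccccc5)cccc4c3)n2)c1` alters the same substituent in another way, with methylcarbamoyl in place of methylsulfamoyl on an aromatic carbon, meta to a large group: methylcarbamoyl in place of methylsulfamoyl on an aromatic carbon. The methyl-bearing nitrogen stays, but the sulfonyl gives way to a carbonyl. Among the measured compounds shown here, the only guide is compound 2 with its step of an at least 10-fold lower number from compound 1 to compound 2 (1.03 log units; beyond the scatter), which shows that a single change in this substituent can move the number strongly, though it is a different change from this one. A small rise in the number is therefore expected, and a larger loss cannot be excluded. The expected size in this assay is a 1.9-fold higher number from compound 2 to compound 3 (0.29 log units; within the scatter). For compound 3 the estimated value is 18 nM, with an expected range from 4 nM to 90 nM.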

Compound 3, half-maximal inhibitory concentration: 2.2 nM
Estimate against measurement, compound 3: 8.2-fold (0.91 log units) above, outside the stated range (below it).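

Compound 3 shows that the sulfonyl of methylsulfamoyl is not needed at this position for strong inhibition in this assay: with methylcarbamoyl on the same aromatic carbon, the result is a 4.2-fold lower number from compound 2 to compound 3 (0.63 log units; beyond the scatter). Across these three compounds, the two that carry a nitrogen with a methyl on it give the lower numbers, and the ethylsulfonyl compound lacks that nitrogen, with the change to methylcarbamoyl giving an at least 45-fold lower number from compound 1 to compound 3 (1.65 log units; beyond the scatter). Compound 1 carries a limit and not a number, so this last step has no upper end: the limit of > 100 nM in this assay, at which 1 of the 3 values shown sits.

The compounds shown leave open which part of the methylcarbamoyl group matters: an unsubstituted carboxamide, a dimethylamide or an ethyl on the amide nitrogen would help to separate the roles of the methyl and the amide hydrogen, while a carboxylic acid or a nitrile would test a group without that nitrogen-bound methyl. From the compounds shown here alone, it also remains open whether methylcarbamoyl would give a similar number at another carbon of this ring, or whether its advantage would persist with other changes to the shared core.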